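The compounds below may be only part of what the source reports. "The series", "measured", "known", "first", "only" and "open" are said of these compounds alone.

Cytotoxicity across this series is read in an ADME assay on HeLa cells (Homo sapiens) for cytotoxicity, read by MTT assay; on this read-out higher numbers stand for weaker inhibition and lower numbers for stronger inhibition. Compound 1 `N#Cc1c(-c2ccccc2Cl)c(C#N)c(=O)n(/N=C/c2cn(-c3ccccc3)nc2-c2ccccc2)c1N` gives > 200 ug/mL in this assay, which is a limit of the assay and not a number. Compound 2 `N#Cc1c(-c2cccc(F)c2)c(C#N)c(=O)n(/N=C/c2cn(-c3ccccc3)nc2-c2ccccc2)c1N` gives > 200 ug/mL in this assay, again only a limit. The step that the two limits leave unreadable from compound 1 to compound 2 is therefore not readable in size or direction; both values rest at the same ceiling, see (the limit of > 200 ug/mL in this assay, at which 2 of the 2 values shown sit). Compound 2 thus stands at the limit, with nothing to rank it against compound 1. Compound 3 `N#Cc1c(-c2ccc([N+](=O)[O-])cc2)c(C#N)c(=O)n(/N=C/c2cn(-c3ccccc3)nc2-c2ccccc2)c1N` differs from compound 2 by 4-nitrophenyl in place of 3-fluorophenyl on an aromatic carbon. For the measured compounds named here, the one measured step at this position is unreadable, so no size or direction for the change can be drawn from it, and the expected step is a number no higher from compound 2 to compound 3 (the limit leaves the size open), none beyond the scatter, with a limit the likely outcome. Compound 3 is estimated at 200 ug/mL, in the range 100 ug/mL to 400 ug/mL.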

Compound 3, half-maximal inhibitory concentration: > 200 ug/mL
Compound 3: a limit, no number (the forecaster's own chance of this, stated with the estimate: 85%); the middle value sits exactly at the limit.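

Compound 3 also sits at a limit, not a number, so the steps among compound 1, compound 2 and compound 3 cannot be read in size or direction: the limit of > 200 ug/mL in this assay, at which 3 of the 3 values shown sit. The compounds shown leave open whether any group at this position gives a measurable number in this assay.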